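The source may hold more compounds than are shown below. What is called first, only, known or untested is meant among the compounds shown, and "the series" means these compounds.

Measured compounds:
compound 1, `O=C(O)/C(S)=C/c1c[nH]c2cccc(F)c12`, 10 nM
compound 2, `O=C(O)/C(S)=C/c1cccc(Cl)c1`, 4200 nM
compound 3, `O=C(O)/C(S)=C/c1c[nH]c2cccc(Br)c12`, 6 nM

In an assay on isolated protein for inhibition of Calpain-1 catalytic subunit (Sus scrofa), read by FRET (on this read-out higher numbers stand for weaker inhibition and lower numbers for stronger inhibition), compound 3 gives 6 nM, the lowest of the three numbers, although the step of a 1.7-fold lower number from compound 1 to compound 3 (0.22 log units; within the scatter) lies within the scatter. For the measured compounds named here, compound 2 gives 4200 nM, far above compound 3, and no single-point step links the two.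

Compound 4 is `O=C(O)/C(S)=C/c1c[nH]c2cccc(Cl)c12`, differing from compound 3 by chloro in place of bromo on an aromatic carbon. Going by the values given here, the only step that bears on this exchange of halogens at the same position is a 1.7-fold lower number from compound 1 to compound 3 (0.22 log units; within the scatter), which stayed within the scatter. Chloro is expected to behave like its neighbours in that series, so for this assay compound 4 is estimated at 8 nM, between 3 nM and 20 nM, with the expected step being a 1.3-fold higher number from compound 3 to compound 4 (0.12 log units; within the scatter), not beyond the scatter.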

Compound 4, half-maximal inhibitory concentration: 20 nM
Compound 4: middle estimate off by 2.5-fold (0.40 log units), on the low side; measured number inside the range.
By their numbers in this assay, from the lowest: compounds 3, 1 and 4 (each within the scatter of the next, the first and the last beyond it); then compound 2.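

For the compounds shown here, with halogens at this position, the exchange is not entirely silent in this assay: a 3.3-fold higher number from compound 3 to compound 4 (0.52 log units; beyond the scatter) is a modest change, and the first halogen step here to pass beyond the scatter. By contrast, a 2.0-fold higher number from compound 1 to compound 4 (0.30 log units; within the scatter) stays within the scatter, so only bromo and chloro are separated, while fluoro cannot be told apart from chloro or from bromo. No evidence at hand explains this difference. Going by these compounds, whether a methyl, a methoxy or an amine at this position would keep the number low remains open, as does whether the same halogen exchange would matter elsewhere on the shared core.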